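The compounds below may be only part of what the source reports. "The series", "measured", "known", "first", "only" and "open" are said of these compounds alone.

Measured so far in a physicochemical assay for lipophilicity, in phosphate buffer, measured as octanol-water partition, with a stated time of 24 h; a lower number here means a more polar compound, a higher number a more lipophilic compound:

- compound 1, `O=[N+]([O-])c1ccc(Oc2ccc(/C=N/NC(=S)Nc3ccc(Br)cc3)cc2)cc1`: compound 1 gives 5.68
- compound 2, `O=[N+]([O-])c1ccc(Oc2ccc(/C=N/NC(=S)Nc3ccc(Cl)cc3)cc2)cc1`: compound 2 gives 5.52
- compound 3, `S=C(N/N=C/c1ccc(Oc2ccc(Cl)cc2)cc1)Nc1ccc(Cl)cc1`: compound 3 gives 6.2

Compound 3 holds the highest of the three numbers, and its gaps to compound 1 and to compound 2 both lie beyond the scatter of this assay. The cores of compound 2 and compound 3 differ by chloro in place of nitro on an aromatic carbon, and this change moved a number 0.68 log units higher from compound 2 to compound 3 (beyond the scatter). The change from compound 2 to compound 1 is bromo in place of chloro on an aromatic carbon, which moved a number 0.16 log units higher from compound 2 to compound 1 (within the scatter).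

Compound 4, `S=C(N/N=C/c1ccc(Oc2ccc(Cl)cc2)cc1)Nc1ccc(Br)cc1`, has not yet been measured. It differs from compound 3 by bromo in place of chloro on an aromatic carbon; the place is described in the same words as for the change from compound 2 to compound 1, so this is the same change made on the other core. Within the data shown here, a step of a number 0.16 log units higher from compound 3 to compound 4 (within the scatter) is expected from compound 3 to compound 4, beside a number 0.16 log units higher from compound 2 to compound 1 (within the scatter), because a number 0.16 log units higher from compound 2 to compound 1 (within the scatter) is the one measured instance of this change. Compound 4 is therefore estimated at 6.36, with a range from 6.05 to 6.67.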

Compound 4, partition coefficient: 6.24
Compound 4: middle estimate off by 0.12 log units, on the high side; measured number inside the range.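

In this assay the swap of bromo for chloro gives a number 0.04 log units higher from compound 3 to compound 4 (within the scatter) and on the other core gives a number 0.16 log units higher from compound 2 to compound 1 (within the scatter) so on neither core can bromo and chloro be told apart, and the change carries across these two cores without a step beyond the scatter. The swap of chloro for nitro also carries, with a number 0.56 log units higher from compound 1 to compound 4 (beyond the scatter) beside a number 0.68 log units higher from compound 2 to compound 3 (beyond the scatter) and both steps beyond the scatter and in the same direction. Among these compounds, this rests on only two pairs for each change, so it does not show that either step would hold on a further core, and nothing measured here bears on why the steps take these sizes.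

Going by these compounds, the places that vary carry only chloro, bromo or nitro, so how an amine, a carboxylic acid or a longer chain would behave there stays open. On these data alone, whether fluoro or iodo would follow the same pattern on these two cores is also open.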